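The source may hold more compounds than are shown below. What is called first, only, known or untested is meant among the compounds shown, and "the series" means these compounds.

In a functional assay on HepG2 cells for inhibition of squalene monooxygenase (Homo sapiens) (a higher number here means a weaker inhibitor, a lower number a stronger inhibitor), compound 3 `CCN(C/C=C/C#CC(C)(C)C)Cc1cccc(OCCN(C)S(=O)(=O)c2ccc(F)cc2)c1` gives 255 nM, the highest of the three numbers: compound 2 `CCN(C/C=C/C#CC(C)(C)C)Cc1cccc(OCCN(C)S(=O)(=O)c2ccsc2)c1` gives 250 nM, and the step of a 1.0-fold higher number from compound 2 to compound 3 (0.01 log units; within the scatter) lies within the scatter, whereas compound 1 `CCN(C/C=C/C#CC(C)(C)C)Cc1cccc(OCCN(C)S(=O)(=O)c2cccs2)c1` gives 60 nM and the step of a 4.3-fold higher number from compound 1 to compound 3 (0.63 log units; beyond the scatter) lies beyond it. Compound 4 `CCN(C/C=C/C#CC(C)(C)C)Cc1cccc(OCCN(C)S(=O)(=O)c2nccs2)c1` carries 1,3-thiazol-2-yl in place of 4-fluorophenyl on a sulfonyl sulfur. The step of a 4.3-fold higher number from compound 1 to compound 3 (0.63 log units; beyond the scatter) shows that a five-membered aromatic ring in this place can give a lower number than 4-fluorophenyl, but the step of a 1.0-fold higher number from compound 2 to compound 3 (0.01 log units; within the scatter) shows it need not. A ring with 2 hetero atoms here has no precedent among these compounds. For compound 4 the expected step is modest, toward a lower number: a 2.1-fold lower number from compound 3 to compound 4 (0.33 log units; beyond the scatter). Compound 4 is expected to give 120 nM, between 45 nM and 320 nM.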

Compound 4, half-maximal inhibitory concentration: 170 nM
For compound 4 the middle estimate is 1.4-fold (0.15 log units) below the measured one; measured number inside the range.
By their numbers in this assay, from the lowest: compound 1; then compounds 4, 2 and 3 (each within the scatter of the next).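

In this assay the steps of a 1.5-fold lower number from compound 3 to compound 4 (0.18 log units; within the scatter) and a 1.5-fold lower number from compound 2 to compound 4 (0.17 log units; within the scatter) show that on the sulfonyl sulfur 1,3-thiazol-2-yl cannot be told apart from 4-fluorophenyl or thiophen-3-yl. Only thiophen-2-yl stands apart, with a 2.8-fold higher number from compound 1 to compound 4 (0.45 log units; beyond the scatter) beyond the scatter, so a five-membered aromatic ring with 2 hetero atoms does not match the number of compound 1 here. Nothing given here accounts for this difference.

On these data alone, whether a 1,3-oxazol-2-yl or pyridin-2-yl ring could match thiophen-2-yl stays open. So does the effect of a chlorine or methyl group on the thiophen-2-yl ring.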